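This account rests on a few compounds, and the source may have more. Where it says the series, first, only, none or still open, it means among the compounds named here.

Working notes on the series: in a functional assay on MCF7 cells (Homo sapiens) for antiproliferative activity, read by MTT assay, with a stated time of 72 h (on this read-out lower numbers stand for stronger inhibition and higher numbers for weaker inhibition), compound 1 `O=C1COc2ccc(-c3cccc(NS(=O)(=O)c4ccc(F)cc4)c3)cc2N1` gives 18300 nM and compound 2 `COc1ncc(-c2ccc3c(c2)NC(=O)CO3)cc1NS(=O)(=O)c1ccc(F)cc1` gives 32300 nM, two values within the scatter of each other. Compound 3 `O=C1COc2ccc(-c3cnc(Cl)c(NS(=O)(=O)c4ccc(F)cc4)c3)cc2N1` reaches only a limit of the assay, > 40000 nM. Compound 4 `COc1ncc(-c2ccc3c(c2)N(c2ccc(Cl)cc2)C(=O)CO3)cc1NS(=O)(=O)c1ccc(F)cc1` differs from compound 2 by 4-chlorophenyl in place of hydrogen on an amide-type nitrogen in a ring. Among the measured compounds shown here, the only measured step, an at least 1.2-fold higher number from compound 2 to compound 3 (0.09 log units; that floor lies within the scatter), leaves that nitrogen unchanged, so no measured step gives a size for this change. Starting from compound 2 at 32300 nM, a moderately lower number beyond the scatter is expected in this assay, on weak grounds. The expected change is a 4.0-fold lower number from compound 2 to compound 4 (0.61 log units; beyond the scatter). For compound 4 the estimated value is 8000 nM, with an expected range of 1500 nM to 35000 nM.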

Compound 4, half-maximal inhibitory concentration: 27600 nM
Estimate against measurement, compound 4: 3.5-fold (0.54 log units) below, and the stated range covers the measured number.
By their numbers in this assay, from the lowest: compounds 1, 4 and 2 (each within the scatter of the next). At a limit, above all of these: compound 3.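

In this assay, 4-chlorophenyl in place of hydrogen on the amide-type nitrogen gives a 1.2-fold lower number from compound 2 to compound 4 (0.07 log units; within the scatter). Among the compounds shown here, this is the first size for this position, where the earlier compounds all carry the hydrogen: the nitrogen takes a six-membered aromatic ring with no step beyond the scatter. Compound 3 remains the only one at a limit: the limit of > 40000 nM in this assay, at which 1 of the 4 values shown sits.

Open, as far as these compounds go, is how a methyl group, or a chain ending in an amine or a carboxylic acid, would read on this nitrogen. Also open, from the compounds shown here alone, is whether 4-chlorophenyl gives the same result on compound 1.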